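Adding chloro to the benzamide phenyl in a hedgehog inhibitor series

The source may report more compounds than this note shows. Statements on the series, on what has been measured and on what is new or still open speak of the compounds shown alone.

The measured compounds are:
compound 1, `Cc1ccc(C(=O)Nc2ccc(Cl)c(-c3ccccn3)c2)c(C)n1`: in an assay on C3H 10T1/2 cells for inhibition of Sonic hedgehog protein (Mus musculus), read by a luciferase reporter (on this read-out lower numbers stand for stronger inhibition and higher numbers for weaker inhibition), compound 1 gives 130 nM.
compound 2, `O=C(Nc1ccc(Cl)c(-c2ccccn2)c1)c1ccccc1`: in this assay compound 2 gives 800 nM.

Among the compounds with values here, compound 2 stands at the higher of the two numbers, and the only measured step, a 6.2-fold higher number from compound 1 to compound 2 (0.79 log units; beyond the scatter), separates it from compound 1. That step exchanges the whole aryl group on the carbonyl carbon, phenyl in place of 2,6-dimethylpyridin-3-yl, and so says nothing about a single substituent on the phenyl.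

Compound 3, `O=C(Nc1ccc(Cl)c(-c2ccccn2)c1)c1ccc(Cl)cc1`, differs from compound 2 by chloro in place of hydrogen on an aromatic carbon, on an aromatic carbon of a six-membered aromatic ring of carbon only; read one bond further out, the change is phenyl to 4-chlorophenyl. Within the data shown here, no measured pair in this set alters a substituent on that ring, so nothing here bears directly on the change. With that in mind, the account expects a 1.3-fold lower number from compound 2 to compound 3 (0.12 log units; within the scatter), a step not beyond the scatter in either direction. Compound 3 is therefore estimated at 600 nM, within a range from 200 nM to 2000 nM.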

Compound 3, half-maximal inhibitory concentration: 1500 nM
Compound 3: middle estimate off by 2.5-fold (0.40 log units), on the low side; the range from low to high includes it.
By their numbers in this assay, from the lowest: compound 1; then compounds 2 and 3 (each within the scatter of the next).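

Placed para to a large group on the phenyl of compound 2, chloro gives a 1.9-fold higher number from compound 2 to compound 3 (0.27 log units; within the scatter) in this assay and so, as the first change of a single substituent on this ring, does not separate the two compounds. Compound 1 remains apart from this chlorinated compound, with a 12-fold higher number from compound 1 to compound 3 (1.06 log units; beyond the scatter) for 4-chlorophenyl in place of 2,6-dimethylpyridin-3-yl on the carbonyl carbon; thus, like the unsubstituted phenyl with a 6.2-fold higher number from compound 1 to compound 2 (0.79 log units; beyond the scatter) in the same exchange, the 4-chlorophenyl group does not reach the number of compound 1. Nothing available here accounts for any of these steps.

On these data alone, it remains open whether another group at this place on the phenyl, such as methoxy, an amine or a carboxylic acid, would give a step beyond the scatter. The compounds shown also leave open how much of the difference from compound 1 belongs to the two methyl groups and how much to the pyridine ring itself, a question that an unsubstituted pyridin-3-yl group on the carbonyl carbon would address.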